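Fluoro in place of hydrogen on the second aryl ring

This account rests on a few compounds, and the source may have more. Where it says the series, first, only, none or still open, it means among the compounds named here.

Measured compounds:
- compound 1 `CC(=O)c1cc(-c2ccc(F)cc2)cc2cc(-c3ccc(F)cc3)[nH]c12`: 9.31%
- compound 2 `CC(=O)c1cc(/C=C/c2ccc(F)cc2)cc2cc(-c3ccccc3)[nH]c12`: 23.9%

Of the compounds shown here, two on the shared core have been measured in a functional assay on HeLa cells (Homo sapiens) for cytotoxicity, read by MTT assay, with a stated time of 2 days, tested at 100 uM; a higher number here means a weaker effect of the compound at the concentration tested, a lower number a stronger effect. Compound 1 gives 9.31%. Compound 2 gives 23.9%, the higher of the two numbers, and its gap to compound 1 lies beyond the usual scatter. Among the compounds with values here, compound 1 and compound 2 differ in more than one place, so no single step between them can be read from these two values alone.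

The next compound to measure is compound 3 `CC(=O)c1cc(/C=C/c2ccc(F)cc2)cc2cc(-c3ccc(F)cc3)[nH]c12`. It keeps the whole of compound 2 except one change: fluoro in place of hydrogen on an aromatic carbon. The place of the change is on an aromatic carbon of a six-membered aromatic ring of carbon only, para to a large group.

Within the data shown here, no measured pair shows this change by itself, so its size is unknown here. The step is expected to be small, at most a modest downward movement or none beyond the scatter, estimated as a number 5.9 percentage points lower from compound 2 to compound 3 (within the scatter). For compound 3 in this assay the expected value is 18%, with a range from 5% to 34%.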

Compound 3, a percentage reported as activity, at one concentration (the size of the read-out at that concentration, not a potency): 20.3%
Compound 3: middle estimate off by 2.3 percentage points, on the low side; low and high end bracket the measured number.
By their numbers in this assay, from the lowest: compound 1; then compounds 3 and 2 (each within the scatter of the next).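

In this assay, the change from phenyl to 4-fluorophenyl, on an aromatic carbon para to a large group, gives a number 3.6 percentage points lower from compound 2 to compound 3 (within the scatter) and so does not separate the two compounds; with the 2-(4-fluorophenyl)ethenyl group in place, fluoro in place of hydrogen at this position has no effect that can be read beyond the usual scatter. Within the data shown here, compound 3 also isolates the other difference between compound 1 and compound 2: 2-(4-fluorophenyl)ethenyl in place of 4-fluorophenyl gives a number 11 percentage points higher from compound 1 to compound 3 (beyond the scatter) and is the only single-place step that lies beyond the scatter. Nothing available on these compounds explains either step.

The compounds shown leave open whether an amine, a methoxy group or a carboxylic acid at the same ring position would move the number beyond the scatter, and whether fluoro in place of hydrogen there would read the same with 4-fluorophenyl in the other place. As far as these compounds go, a longer chain in place of the ethenyl link also remains open, and each number tells only of a stronger or weaker effect at the one concentration tested.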